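Replacing Pyridin-2-yl with 2,3-Difluorophenyl on a Shared Core

The source may report more compounds than this note shows. Statements on the series, on what has been measured and on what is new or still open speak of the compounds shown alone.

Measured compounds:
compound 1 `CC(C)(C)Cc1csc(N)c1C(=O)c1ccc(Cl)cc1` gives 1%
compound 2 `CC(C)(C)Cc1c(-c2ccccn2)sc(N)c1C(=O)c1ccc(Cl)cc1` gives 1%

Of the compounds shown here, two have been measured in an assay on CHO cells for displacement of a labelled ligand from adenosine receptor A1 (Homo sapiens), read by scintillation counting, tested at 10 uM (on this read-out lower numbers stand for less inhibition and higher numbers for more inhibition at the one concentration tested (going by the name of the read-out)), so far. Compound 1 gives 1% in this assay, and compound 2 gives 1%. The step of no change at the digits printed from compound 1 to compound 2 (within the scatter) shows that adding a six-membered ring with one nitrogen to the shared core left the read-out where it was, at the low end of the scale. Compound 2 therefore stands level with compound 1, both showing hardly any displacement of the labelled ligand.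

Compound 3 `CC(C)(C)Cc1c(-c2cccc(F)c2F)sc(N)c1C(=O)c1ccc(Cl)cc1` is the next compound to be measured. It differs from compound 2 in one place: 2,3-difluorophenyl in place of pyridin-2-yl on an aromatic carbon. Among the compounds with values here, the only step that bears on this change is the one from compound 1 to compound 2, which put an aromatic ring on the same carbon of the shared core and produced no change beyond the scatter. Within the data shown here, with both measured compounds sitting at the bottom of the scale and the one relevant step flat, the expected step of a number 2 percentage points higher from compound 2 to compound 3 (within the scatter) is none beyond the scatter. Compound 3 is therefore estimated to give 3% in this assay, with a range from -6% to 14%.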

Compound 3, a percentage reported as inhibition, at one concentration (the size of the read-out at that concentration, not a potency): 1%
Beside the measured number, compound 3's estimate is 2 percentage points above it, within the range that was stated.
By their numbers in this assay, from the lowest: compounds 1, 2 and 3 (each within the scatter of the next).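

In this assay, exchanging pyridin-2-yl, a ring with one hetero atom and one hydrogen-bond acceptor, for 2,3-difluorophenyl, a ring of carbon only with no hydrogen-bond acceptor, gives no change at the digits printed from compound 2 to compound 3 (within the scatter). Set against the plain hydrogen on this aromatic carbon next to the ring sulfur, the result is again flat, with no change at the digits printed from compound 1 to compound 3 (within the scatter), so two different six-membered aromatic rings at this position now give the same picture, and all three compounds stay at the low end of the scale. Nothing available here accounts for this flat result.

On these data alone, these three compounds show no group at this position that raises the inhibition, so it remains open whether an amine or a carboxylic acid on the same carbon would move the read-out at all. It is equally open whether this position would respond differently if the neopentyl group on the neighbouring ring atom were replaced by a shorter chain, such as ethyl, since every compound shown carries the neopentyl group.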